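A few compounds are considered here, and "the series" means these few. Any claim that something is new, unique, unknown or untested is made for them only; others in the source may bear on it.

Of the compounds shown here, three built on one shared core have been tested in a functional assay on U2OS cells (Homo sapiens) for antiproliferative activity, read by MTT assay, with a stated time of 72 h; a lower number here means a stronger inhibitor, a higher number a weaker inhibitor. Compound 1 `O=C(CSc1ncccn1)Nc1ccc2nc(NC(=O)c3ccc(C(F)(F)F)cc3)sc2c1` gives 28100 nM, compound 2 `O=C(CSc1cccc(O)c1)Nc1ccc2nc(NC(=O)c3ccc(C(F)(F)F)cc3)sc2c1` gives 630 nM, and compound 3 `O=C(CSC1CCCCC1)Nc1ccc2nc(NC(=O)c3ccc(C(F)(F)F)cc3)sc2c1` gives 12300 nM. These three differ only in the group carried on the sulfur, and the steps between them are large: there is a 45-fold lower number from compound 1 to compound 2 (1.65 log units; beyond the scatter), a 2.3-fold lower number from compound 1 to compound 3 (0.36 log units; beyond the scatter), and a 20-fold higher number from compound 2 to compound 3 (1.29 log units; beyond the scatter). Compound 2 therefore holds the lowest number of the three, and both other compounds stand clearly apart from it.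

Compound 4 `Cc1ccc(C(=O)Nc2nc3ccc(NC(=O)CSc4cccc(O)c4)cc3s2)cc1` keeps the 3-hydroxyphenyl on the sulfur that compound 2 carries and is altered at the opposite end of the shared core instead: methyl in place of trifluoromethyl on an aromatic carbon. Within the data shown here, none of the measured steps touches this part of the molecule; all three concern the group on the sulfur, so they show how far a single change can move the number in this assay but say nothing about the direction of this one. With no measured guidance for this position, the expectation for compound 4 is a number close to that of compound 2, a step of a 1.7-fold higher number from compound 2 to compound 4 (0.24 log units; within the scatter) in this assay. Compound 4 is accordingly estimated at 1100 nM in this assay, within a range from 300 nM to 4500 nM.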

Compound 4, half-maximal inhibitory concentration: 12400 nM
Estimate against measurement, compound 4: 11-fold (1.05 log units) below; measured number outside the range, above it.
By their numbers in this assay, from the lowest: compound 2; then compounds 3 and 4 (each within the scatter of the next); then compound 1.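

Until now, only the group on the sulfur had been seen to move the number, but this result shows that the other end of the molecule matters as well. In this assay there is a 20-fold higher number from compound 2 to compound 4 (1.29 log units; beyond the scatter) when 4-(trifluoromethyl)phenyl gives way to 4-methylphenyl, a swap that takes four heavy atoms down to one and leaves the hydrogen-bond donor and acceptor counts unchanged, and this single change moves the number about as far as replacing 3-hydroxyphenyl with cyclohexyl on the sulfur (a 20-fold higher number from compound 2 to compound 3 (1.29 log units; beyond the scatter)). Nothing measured here explains why the methyl compound sits so much higher in this assay.

On these data alone, this position is described by a single pair, so it remains open whether other groups in the same place, such as chlorine, methoxy or a nitrile, would stay near compound 2 or climb toward compound 4. It is also unknown whether the same swap would produce a step of similar size with pyrimidin-2-yl or cyclohexyl on the sulfur, which would show whether the two ends of the molecule act independently.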